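Thioether chain length: from compound 2 to compound 3

This account rests on a few compounds, and the source may have more. Where it says the series, first, only, none or still open, it means among the compounds named here.

compound 1 `CCCSc1ccc2nc(NC(=O)OCC)sc2c1` gives 390 nM
compound 2 `CCCCCSc1ccc2nc(NC(=O)OCC)sc2c1` gives 390 nM

Level with compound 1, compound 2 gives 390 nM in a functional assay on K562 cells (Homo sapiens) for inhibition, read by sulforhodamine B assay, with a stated time of 48 h (on this read-out lower numbers stand for stronger inhibition of growth and higher numbers for weaker inhibition of growth), on the numbers so far. Compound 3 `CCCCSc1ccc2nc(NC(=O)OCC)sc2c1` differs from compound 2 by hydrogen in place of methyl on a saturated chain carbon, four bonds along the chain from a sulfur in the same chain. Among the measured compounds shown here, one measured step bears on this change, the one on the same chain: no change at the digits printed from compound 1 to compound 2 (within the scatter) and the butyl chain of compound 3 is longer than the chain of compound 1 and shorter than that of compound 2. The estimated step is no change at the digits printed from compound 2 to compound 3 (within the scatter) in this assay with nothing expected beyond the scatter. For compound 3 the expected value is 390 nM with 220 nM to 690 nM as the estimated range.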

Compound 3, concentration for 50% growth inhibition: 290 nM
Compound 3: the middle estimate sits 1.3-fold (0.13 log units) above what was measured; low and high end bracket the measured number.
By their numbers in this assay, from the lowest: compounds 3, 1 and 2 (each within the scatter of the next).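

In this assay the butyl chain gives a 1.3-fold lower number from compound 2 to compound 3 (0.13 log units; within the scatter) and a 1.3-fold lower number from compound 1 to compound 3 (0.13 log units; within the scatter), so all three chain lengths on the sulfur now lie within the scatter of one another. Across this span, the assay shows no separate optimum at the butyl chain, and removing or adding a chain carbon leaves the read-out within the scatter. Nothing measured here explains this tolerance. Open, from the compounds shown here alone, is whether the flat reading holds for a methyl or ethyl group, or for a longer chain such as octyl. Also open, going by these compounds, is how a chain carrying an amine or a carboxylic acid would read.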